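Will a Longer Chain Change Compound 4?

A few compounds are considered here, and "the series" means these few. Any claim that something is new, unique, unknown or untested is made for them only; others in the source may bear on it.

In a functional assay on HCT-116 cells (Homo sapiens) for antiproliferative activity, read by MTT assay, with a stated time of 48 h (on this read-out lower numbers stand for stronger inhibition and higher numbers for weaker inhibition), compound 1 `CCCC(CCO)n1cnc2c(Cl)nc(F)nc21` gives 16500 nM and compound 2 `CCCCCC(CCO)n1cnc2c(Cl)nc(F)nc21` gives 8660 nM while compound 3 `CCCCCCCC(CCO)n1cnc2c(Cl)nc(F)nc21` gives 17600 nM on the same scale. Compound 3 thus shares the high end of these numbers with compound 1. Among the compounds with values here, compound 4 `CCCCCCCCCC(CCO)n1cnc2c(Cl)nc(F)nc21` lengthens the chain again, with ethyl in place of hydrogen on a saturated chain carbon, eight bonds along the chain from an aromatic nitrogen as its only change. Within the data shown here, three measured steps bear on it: a 1.9-fold lower number from compound 1 to compound 2 (0.28 log units; within the scatter) and a 2.0-fold higher number from compound 2 to compound 3 (0.31 log units; beyond the scatter) for ethyl additions, and a 1.1-fold higher number from compound 1 to compound 3 (0.03 log units; within the scatter) for a butyl addition. These small steps show no steady trend, so in this assay only a slight rise, within the scatter, is expected. The estimated step is a 1.1-fold higher number from compound 3 to compound 4 (0.06 log units; within the scatter) and no larger. Compound 4 is expected at 20000 nM with an estimated range of 9000 nM to 45000 nM in this read-out.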

Compound 4, half-maximal inhibitory concentration: 32100 nM
For compound 4 the middle estimate is 1.6-fold (0.21 log units) below the measured one; the measured number falls inside the stated range.
By their numbers in this assay, from the lowest: compounds 2, 1, 3 and 4 (each within the scatter of the next, the first and the last beyond it).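

In this assay the ethyl addition at this chain carbon gives a 1.8-fold higher number from compound 3 to compound 4 (0.26 log units; within the scatter) and the hexyl addition gives a 1.9-fold higher number from compound 1 to compound 4 (0.29 log units; within the scatter) so neither of these two steps leaves the scatter. The same ethyl addition does not act alike along the chain: the same change on two cores in this assay, a 1.9-fold lower number (0.28 log units; within the scatter) from compound 1 to compound 2 and a 1.8-fold higher number (0.26 log units; within the scatter) from compound 3 to compound 4, 3.5-fold (0.54 log units) apart, beyond the scatter of two such steps. The butyl addition gives a 3.7-fold higher number from compound 2 to compound 4 (0.57 log units; beyond the scatter) and it too depends on the chain it lengthens: the same change on two cores in this assay, a 1.1-fold higher number (0.03 log units; within the scatter) from compound 1 to compound 3 and a 3.7-fold higher number (0.57 log units; beyond the scatter) from compound 2 to compound 4, 3.5-fold (0.54 log units) apart, beyond the scatter of two such steps.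

On these data alone, whether a still longer chain would keep this course remains open. So does the effect of an amine or a carboxylic acid carried on the chain.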